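Allyl to Butyl: One Step on DU-145 Cells

A few compounds are considered here, and "the series" means these few. Any claim that something is new, unique, unknown or untested is made for them only; others in the source may bear on it.

Measured compounds:
compound 1, `C=CCNC(=O)c1ccccc1[Se][Se]c1ccccc1C(=O)NCC=C`: 20400 nM
compound 2, `C=CCn1[se]c2ccccc2c1=O`: 10300 nM

Of the compounds shown here, two have been measured in a functional assay on DU-145 cells (Homo sapiens) for cytotoxicity, read by sulforhodamine B assay, with a stated time of 24 h; on this read-out higher numbers stand for weaker inhibition and lower numbers for stronger inhibition. Compound 1, the open diselenide `C=CCNC(=O)c1ccccc1[Se][Se]c1ccccc1C(=O)NCC=C`, gives 20400 nM in this assay. Compound 2, the cyclic compound `C=CCn1[se]c2ccccc2c1=O`, gives 10300 nM in this assay. For the measured compounds named here, the two numbers sit within the usual scatter of each other, so nothing separates compound 1 from compound 2 beyond the noise of repeated measurement; no single-change step between them is defined, since they differ in more than one place.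

Compound 3, `CCCCn1[se]c2ccccc2c1=O`, is not yet measured. It differs from compound 2 in one place: propyl in place of vinyl on a saturated chain carbon bound to an aromatic nitrogen. Going by the values given here, nothing measured so far bears on what such a change on the chain bound to the aromatic nitrogen does in this assay. The change is small in size and adds no donor or acceptor, so the expectation is a step from compound 2 to compound 3 of a 1.2-fold higher number from compound 2 to compound 3 (0.07 log units; within the scatter) in this assay, that is, none beyond the scatter. On that basis compound 3 is estimated at 12000 nM in this assay, with a range from 5000 nM to 30000 nM.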

Compound 3, half-maximal inhibitory concentration: 20800 nM
For compound 3 the middle estimate is 1.7-fold (0.24 log units) below the measured one; measured number inside the range.
By their numbers in this assay, from the lowest: compounds 2, 1 and 3 (each within the scatter of the next, the first and the last beyond it).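

For the compounds shown here, the step of a 2.0-fold higher number from compound 2 to compound 3 (0.31 log units; beyond the scatter) in this assay is the first reading at this place, on a saturated chain carbon bound to an aromatic nitrogen, and it shows that the change from allyl to butyl on the shared core is not silent, though the step is modest. Compounds 1 and 2 differ in more than one place, so they could not show what the chain alone does; this pair shows that a higher number, which here means weaker inhibition, comes with the loss of the double bond and the change to the butyl chain. No measurement shown accounts for this step, and this single pair cannot tell the loss of the double bond apart from the change in chain length.

The compounds shown leave open whether a longer chain such as hexyl, a branched chain such as isopropyl, or a chain ending in an amine or a carboxylic acid would raise the number further or lower it again. They also leave open whether a butyl group on the amide nitrogen of the open diselenide would give a comparable step from compound 1.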